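Swapping an aryl ether for an aryl thioether on a quinoxaline-type core

The source may hold more compounds than are shown below. What is called first, only, known or untested is meant among the compounds shown, and "the series" means these compounds.

Measured compounds:
compound 1 `Nc1cc(N)c2nc(-c3ccccc3)c(Oc3ccc(Cl)c(Cl)c3)nc2c1`: 72400 nM
compound 2 `CCOC(=O)[C@H](CCC(=O)O)NC(=O)c1ccc(Sc2nc3cc(N)cc(N)c3nc2-c2ccccc2)cc1`: < 100000 nM

Within the data shown here, in a functional assay on LOX IMVI cells (Homo sapiens) for inhibition, read by sulforhodamine B assay, with a stated time of 48 h (on this read-out lower numbers stand for higher toxicity in this test and higher numbers for lower toxicity in this test), compound 1 gives 72400 nM, the only plain number in this set. For compound 2 this assay gives only a limit, < 100000 nM, so no number stands beside it, as the entry the limit of < 100000 nM in this assay, at which 1 of the 2 values shown sits, shows. Compound 1 is therefore the sole anchor. Compound 3 `Nc1cc(N)c2nc(-c3ccccc3)c(Sc3ccc(F)cc3)nc2c1` is not yet measured. It differs from compound 1 by (4-fluorophenyl)sulfanyl in place of 3,4-dichlorophenoxy on an aromatic carbon. Among the measured compounds shown here, no measured pair tells how such a change shifts this assay, and the two values shown give no step to lean on. With only compound 1 as reference, the step from compound 1 to compound 3 is expected to be small and is estimated as a 1.0-fold lower number from compound 1 to compound 3 (0.01 log units; within the scatter), most likely within the scatter in either direction. Compound 3 is expected to give about 70000 nM in this assay, within a range of 25000 nM to 200000 nM.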

Compound 3, concentration lethal to 50% of the cells: 74100 nM
For compound 3 the middle estimate is 1.1-fold (0.02 log units) below the measured one; the range from low to high includes it.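

The exchange of 3,4-dichlorophenoxy for (4-fluorophenyl)sulfanyl gives a 1.0-fold higher number from compound 1 to compound 3 (0.01 log units; within the scatter) in this assay. Among these compounds, this is the first readable step at this aromatic carbon, next to the ring nitrogen and ortho to a phenyl group, and on this read-out the two groups cannot be told apart there. The exchange alters the linking atom and the halogens on the outer ring together, so the step assigns nothing to either alone.

Among the compounds shown here, for compound 2 the entry is a limit and not a number, so it adds no second step: the limit of < 100000 nM in this assay, at which 1 of the 3 values shown sits. Whether an amine, a carboxylic acid or a longer chain on this same carbon would move the number beyond the scatter stays open, as does the effect of the oxygen-to-sulfur exchange with the outer ring held constant.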